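This account rests on a few compounds, and the source may have more. Where it says the series, first, only, none or still open, it means among the compounds named here.

Measured so far in a functional assay (Cavia porcellus) with sulfonylurea receptors; K-ATP channels (Homo sapiens) as the target; a higher number here means a weaker inhibitor, a lower number a stronger inhibitor:

Compound 1 `CC(O)(C(=O)Nc1ccc(S(=O)(=O)c2ccccc2Cl)cc1)C(F)(F)F`: 2300 nM
Compound 3 `CC(O)(C(=O)Nc1ccc(C(=O)c2ccccc2F)cc1)C(F)(F)F`: 2300 nM
Compound 2 `CC(O)(C(=O)Nc1ccc(S(=O)(=O)c2ccccc2)c(C(=O)O)c1)C(F)(F)F`: > 30000 nM, which is a limit of the assay and not a number.

Compound 1 stands level with compound 3 at the digits shown, and the gap between them lies within the scatter of the assay, so no order can be read between the two. Compound 2 sits at the limit of > 30000 nM in this assay, at which 1 of the 3 values shown sits.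

The step under study leads from compound 1 to compound 4 `CC(O)(C(=O)Nc1ccc(S(=O)(=O)c2nccs2)cc1)C(F)(F)F`. The change is 1,3-thiazol-2-yl in place of 2-chlorophenyl on a sulfonyl sulfur. For the measured compounds named here, no step between two measured compounds of this kind is available, so the size of the step can only be expected. A small shift toward weaker inhibition in this assay is expected, of a size that may not clear the scatter, as the step from compound 1 to compound 4 is estimated at a 1.5-fold higher number from compound 1 to compound 4 (0.18 log units; within the scatter). Compound 4 is therefore expected to give 3500 nM, within a range from 1000 nM to 12000 nM.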

Compound 4, half-maximal inhibitory concentration: 1400 nM
Compound 4: middle estimate off by 2.5-fold (0.40 log units), on the high side, and the stated range covers the measured number.
By their numbers in this assay, from the lowest: compounds 4, 1 and 3 (each within the scatter of the next). At a limit, above all of these: compound 2.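

In this assay, putting 1,3-thiazol-2-yl in place of 2-chlorophenyl on a sulfonyl sulfur gives a 1.6-fold lower number from compound 1 to compound 4 (0.22 log units; within the scatter), the only step shown between two compounds that differ in one place. The group at this position can therefore go from a six-membered aromatic ring of carbon only to a five-membered aromatic ring with 2 hetero atoms, and the two compounds stay within the scatter of each other, even though the entering group carries 2 hydrogen-bond acceptors and the leaving group carries none. Nothing measured here bears on why the step comes out this way.

The compounds shown leave open how a non-aromatic group such as a piperidine or a plain methyl would read on the same sulfonyl sulfur in this assay. Going by these compounds, it also remains open whether a 1,3-thiazol-2-yl carrying an amine would stay within the scatter of compound 4.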